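The source may hold more compounds than are shown below. What is called first, only, known or untested is meant among the compounds shown, and "the series" means these compounds.

Measured so far:

compound 1, `Cc1cccc(Nc2nc3c(=O)[nH]c(C)nc3s2)c1`: 12%
compound 2, `Cc1nc2sc(Nc3cccc(Cl)c3)nc2c(=O)[nH]1`: 44%
compound 3, `CCOc1nc(C)nc2sc(-c3ccc(C)cc3)nc12`: 1%

All three numbers come from an assay on CHO cells for displacement of a labelled ligand from adenosine receptor A1 (Homo sapiens), read by scintillation counting, with a stated time of 120 min, tested at 1 uM; a lower number here means less inhibition, a higher number more inhibition at the concentration tested (going by the name of the read-out). Between compound 1 and compound 2 the only change is chloro in place of methyl on an aromatic carbon, and this one change made the step of a number 32 percentage points higher from compound 1 to compound 2 (beyond the scatter). Compound 3 rests on a different core from compound 1; how the two cores differ is not broken down here, and in this assay compound 3 gives the lowest of the three numbers.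

Compound 4, `CCOc1nc(C)nc2sc(-c3ccc(Cl)cc3)nc12`, has not yet been measured. It differs from compound 3 by chloro in place of methyl on an aromatic carbon. Within the data shown here, this is the same kind of change as the one from compound 1 to compound 2, but not the same: in compound 2 the chloro sits meta to a large group, in compound 4 it sits para to a large group, and the cores carrying the change are different. Among the measured compounds shown here, only one measured example of the change exists, so there is little to go on. Because compound 3 gives 1%, a number at the bottom of the range, the step is expected to be smaller than the earlier one, and the estimated step from compound 3 to compound 4 is a number 9 percentage points higher from compound 3 to compound 4 (within the scatter). For compound 4 the expected number in this assay is 10%, estimated to lie between 0% and 30%.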

Compound 4, a percentage reported as inhibition, at one concentration (the size of the read-out at that concentration, not a potency): 6%
The estimate for compound 4 lay 4 percentage points above the measured number, within the range that was stated.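

In this assay, chloro in place of methyl on an aromatic carbon gives a number 5 percentage points higher from compound 3 to compound 4 (within the scatter), so on this core the swap produces no change that can be told apart from the ordinary spread of repeated measurements. Set beside the earlier example, the same swap clearly does not bring the same step on both cores: the same change on two cores in this assay, a number 32 percentage points higher (beyond the scatter) from compound 1 to compound 2 and a number 5 percentage points higher (within the scatter) from compound 3 to compound 4, 27 percentage points apart, beyond the scatter of two such steps This shows that the large step seen on the core of compound 1 cannot simply be assumed to carry over to another core, but it does not show what sets the two steps apart, since the two pairs differ in their cores and also in where the chloro sits, which in compound 4 is para to a large group, and two pairs cannot separate these differences or establish a rule for the series.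

The compounds shown leave open whether chloro para to a large group on the core of compound 1 would bring a step like the one on that core or one like the step on the core of compound 3. They also leave open whether an amine or a carboxylic acid in that same place, or a longer chain in place of the ethoxy group, would move the number on the core of compound 3.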